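Ethoxycarbonyl in Place of Propyl: Expecting a Weaker Inhibitor

The source may report more compounds than this note shows. Statements on the series, on what has been measured and on what is new or still open speak of the compounds shown alone.

Among the compounds with values here, in a functional assay on B16 cells (Mus musculus) for inhibition (a lower number here means a stronger inhibitor, a higher number a weaker inhibitor), compound 2 (`CCCC(=O)Nc1cccc(C(=O)/C=C/c2ccc(O)c(OC)c2)c1`) gives 1.43 ug/mL, the lowest of the two numbers so far, while compound 1 (`COC(=O)C(=O)Nc1cccc(C(=O)/C=C/c2ccc(O)c(OC)c2)c1`) gives 4.41 ug/mL. Compound 3 (`CCOC(=O)C(=O)Nc1cccc(C(=O)/C=C/c2ccc(O)c(OC)c2)c1`) is reached through (ethoxycarbonyl in place of propyl on a carbonyl carbon), that is, ethoxycarbonyl in place of propyl on a carbonyl carbon. Within the data shown here, the one measured step bearing on this is a 3.1-fold lower number from compound 1 to compound 2 (0.49 log units; beyond the scatter), where propyl took the place of methoxycarbonyl. Going back the other way, a rise of similar, modest size is expected in this assay. The expected step is a 2.8-fold higher number from compound 2 to compound 3 (0.45 log units; beyond the scatter). For compound 3 the estimate is 4 ug/mL, with an expected range of 2 ug/mL to 8 ug/mL.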

Compound 3, half-maximal inhibitory concentration: 7.03 ug/mL
Beside the measured number, compound 3's estimate is 1.8-fold (0.24 log units) below it, within the range that was stated.
By their numbers in this assay, from the lowest: compound 2; then compounds 1 and 3 (each within the scatter of the next).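

Ethoxycarbonyl in place of propyl gives a 4.9-fold higher number from compound 2 to compound 3 (0.69 log units; beyond the scatter) in this assay and so, like methoxycarbonyl, stands apart from propyl on this carbonyl carbon. The added methyl gives a 1.6-fold higher number from compound 1 to compound 3 (0.20 log units; within the scatter) and so leaves compound 1 and compound 3 indistinguishable here. No evidence at hand explains the gap between propyl and the two esters. Still open, on these data alone, is whether a carboxylic acid or a primary amide on this carbonyl carbon would read with propyl or with the esters, and where a longer chain such as pentyl would fall.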